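The compounds below may be only part of what the source reports. "The series", "measured", "known", "first", "only" and "open" are said of these compounds alone.

Measured compounds:
compound 1 `O=C(/C=C/c1ccc(/C=C/C(=O)c2cc(Cl)ccc2Cl)o1)NO` gives 27100 nM
compound 2 `O=C(/C=C/c1ccc(/C=C/C(=O)c2ccc(Cl)cc2)o1)NO` gives 98100 nM
compound 3 `O=C(NO)c1ccc(/C=C/c2cccc(Cl)c2Cl)o1` gives 23600 nM

All three numbers come from a functional assay on A549 cells (Homo sapiens) for antiproliferative activity, read by MTT assay, with a stated time of 48 h; on this read-out lower numbers stand for stronger inhibition and higher numbers for weaker inhibition. Compound 2 has the highest number of the three, and both compound 1 and compound 3 sit below it beyond the scatter. Compound 4 `O=C(/C=C/c1ccc(/C=C/C(=O)c2ccccc2)o1)NO` is not yet measured. Compared with compound 2 it carries hydrogen in place of chloro on an aromatic carbon. Among the compounds with values here, no measured pair in this set shows that single change, so no step for it is known, and the other two compounds differ from compound 2 in more than one place. In this assay a small step is expected for compound 4, if any, leaning toward a somewhat higher number but close to the scatter. Compound 4 is estimated at 110000 nM, within 45000 nM to 270000 nM, which amounts to an expected step of a 1.1-fold higher number from compound 2 to compound 4 (0.05 log units; within the scatter).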

Compound 4, half-maximal inhibitory concentration: 20200 nM
Compound 4: middle estimate off by 5.4-fold (0.74 log units), on the high side; measured number outside the range, below it.
By their numbers in this assay, from the lowest: compounds 4, 3 and 1 (each within the scatter of the next); then compound 2.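

In this assay, replacing chloro with hydrogen on the aromatic carbon para to a large group gives a 4.9-fold lower number from compound 2 to compound 4 (0.69 log units; beyond the scatter). Within the data shown here, this is the first single-place step, and it shows that here the 4-chlorophenyl group carries a cost relative to phenyl rather than a gain. No measured evidence bears on the origin of this step. Open, on these data alone, is whether the cost is specific to chloro or recurs with another group at this place, such as fluoro, methyl or methoxy. Also open, as far as these compounds go, is whether a chloro at another ring carbon behaves alike.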